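The compounds below may be only part of what the source reports. "The series", "measured", "known", "first", "only" and "open" are said of these compounds alone.

Measured so far:
compound 1, `CC(C)c1ccc(Nc2ccc3c(OCCCN4CCN(C)CC4)cccc3n2)cc1`, 6620 nM in a functional assay on cells (Panel melanoma (Carcinoma cell lines), Homo sapiens) for inhibition, read by sulforhodamine B assay, with a stated time of 48 h; on this read-out lower numbers stand for stronger inhibition of growth and higher numbers for weaker inhibition of growth
compound 2, `CN1CCN(CCCOc2cccc3nc(Nc4ccc(F)c(F)c4)ccc23)CC1`, 1690 nM

Going by the values given here, compound 2 holds the lowest of the two numbers; the change a 3.9-fold lower number from compound 1 to compound 2 (0.59 log units; beyond the scatter) is the only measured step. Among the compounds with values here, compound 3, `CN1CCN(CCCOc2cccc3nc(Nc4cccc(Cl)c4)ccc23)CC1`, is not yet measured. 3-chlorophenyl in place of 3,4-difluorophenyl on a nitrogen on an aromatic ring No measured step replaces one halogenated phenyl ring by another, so the step from compound 1 to compound 2 gives only indirect guidance and no clear direction can be drawn. For compound 3 the number in this assay is expected to stay close to that of compound 2, with the step of a 1.2-fold higher number from compound 2 to compound 3 (0.07 log units; within the scatter) estimated as small, giving an estimate of 2000 nM within 700 nM to 6000 nM.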

Compound 3, concentration for 50% growth inhibition: 1760 nM
Estimate against measurement, compound 3: 1.1-fold (0.06 log units) above; the measured number falls inside the stated range.
By their numbers in this assay, from the lowest: compounds 2 and 3 (each within the scatter of the next); then compound 1.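

In this assay, exchanging one halogenated ring for another on this nitrogen gives a 1.0-fold higher number from compound 2 to compound 3 (0.02 log units; within the scatter), so 3-chlorophenyl and 3,4-difluorophenyl cannot be told apart here, although one carries a single chlorine and the other two fluorines. Set against the 4-isopropylphenyl of compound 1, 3-chlorophenyl gives a 3.8-fold lower number from compound 1 to compound 3 (0.58 log units; beyond the scatter), a step like the one seen with 3,4-difluorophenyl. Nothing measured here explains these results. The compounds shown leave open whether a plain phenyl ring, or a phenyl ring carrying a methoxy group or a carboxylic acid, would match these halogenated rings.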